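Series notes: step from compound 2 to compound 3

A few compounds are considered here, and "the series" means these few. Any claim that something is new, unique, unknown or untested is made for them only; others in the source may bear on it.

Measured so far:
compound 1, `Cc1nn(C)c(Oc2ccc(I)cc2)c1/C=N\CCCCCOc1cc2oc(=O)cc(C)c2cc1Cl`: > 25000 nM
compound 2, `Cc1nn(C)c(Oc2ccc(F)c(F)c2)c1/C=N\CCCCCCOc1cc2oc(=O)cc(C)c2cc1Cl`: > 25000 nM

In a functional assay on U-87MG ATCC cells for antiproliferative activity against U-87 MG (Homo sapiens), read by MTT assay, with a stated time of 72 h (on this read-out higher numbers stand for weaker inhibition and lower numbers for stronger inhibition), compound 1 gives > 25000 nM, which is a limit of the assay and not a number. In this assay compound 2 also gives only > 25000 nM, again a limit rather than a number. Compound 2 therefore stands at no measured value; both results obtained so far sit at the limit of > 25000 nM in this assay, at which 2 of the 2 values shown sit. Going by the values given here, no step between measured compounds can be drawn.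

Compound 3, `Cc1ccccc1Oc1c(/C=N\CCCCCCOc2cc3oc(=O)cc(C)c3cc2Cl)c(C)nn1C`, differs from compound 2 by 2-methylphenyl in place of 3,4-difluorophenyl on an oxygen on an aromatic ring. With both known results at the limit, the series gives no direction for this change. For compound 3 the step from compound 2 is expected to be a step that the limit leaves unreadable from compound 2 to compound 3, that is none beyond the scatter, and a further limit is the most probable outcome. For compound 3 the estimate in this assay is 30000 nM, with a range from 8000 nM to 100000 nM.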

Compound 3, half-maximal inhibitory concentration: 9610 nM
Compound 3: middle estimate off by 3.1-fold (0.49 log units), on the high side; measured number inside the range.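

In this assay, 2-methylphenyl in place of 3,4-difluorophenyl on an oxygen on an aromatic ring gives an at least 2.6-fold lower number from compound 2 to compound 3 (0.41 log units; beyond the scatter), the only change shown that yields a number rather than a limit. The read-out therefore responds to the group at this position, with the rest of compound 2 held constant. The true size of the step stays unknown because the value for compound 2 is a limit and not a number: the limit of > 25000 nM in this assay, at which 2 of the 3 values shown sit.

This single pair cannot separate the entry of the methyl group from the loss of the two fluorines. Also open, on these data alone, is where a plain phenyl on the same oxygen would fall, and whether a methoxy group on that ring would move the read-out further.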